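A hydroxyphenyl amide on the shared core

The compounds below may be only part of what the source reports. "The series", "measured", "known", "first", "only" and "open" are said of these compounds alone.

Compound 1 `COc1cccc(NC(=O)c2c(NO)cc(-c3ccccc3)oc2=O)c1` is measured in an ADME assay on Huh-7 cells (Homo sapiens) for cytotoxicity, with a stated time of 3 days; a higher number here means that more compound is tolerated, a lower number that less compound is tolerated. In this assay compound 1 gives only a limit of the assay, > 20000 nM. Compound 2 `CCOc1ccccc1NC(=O)c1c(NO)cc(-c2ccccc2)oc1=O` likewise sits at a limit in this assay, giving > 20000 nM. Compound 3 `O=C(Nc1cccc(C(F)(F)F)c1)c1c(NO)cc(-c2ccccc2)oc1=O` gives 19000 nM in this assay. The step that the two limits leave unreadable from compound 1 to compound 2 cannot be read, because of the limit of > 20000 nM in this assay, at which 2 of the 3 values shown sit. The step of an at least 1.0-fold lower number from compound 1 to compound 3 (0.02 log units; that floor lies within the scatter) stays within the scatter. Compound 4 `O=C(Nc1ccccc1O)c1c(NO)cc(-c2ccccc2)oc1=O` is not yet measured; it differs from compound 1 by 2-hydroxyphenyl in place of 3-methoxyphenyl on an amide-type nitrogen. Within the data shown here, no measured step covers this change, so no shift beyond the scatter is expected. Compound 4 is therefore estimated at 20000 nM, between 8000 nM and 40000 nM. This estimate means a number no higher from compound 1 to compound 4 (the limit leaves the size open), expected to lie within the scatter.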

Compound 4, half-maximal cytotoxic concentration: 14000 nM
Compound 4: middle estimate off by 1.4-fold (0.15 log units), on the high side, and the stated range covers the measured number.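

In this assay, 2-hydroxyphenyl on the amide-type nitrogen brings the series a second number rather than a limit, with an at least 1.4-fold lower number from compound 1 to compound 4 (0.15 log units; that floor lies within the scatter). Hydrogen in place of ethyl on the oxygen on the aromatic ring gives an at least 1.4-fold lower number from compound 2 to compound 4 (0.15 log units; that floor lies within the scatter). Both steps are only floors, so neither shows a shift beyond the scatter, because the starting compounds sit at a limit: the limit of > 20000 nM in this assay, at which 2 of the 4 values shown sit.

Going by these compounds, the true size of both steps stays open. So does whether an amine or a carboxylic acid in place of the hydroxy group would move the number beyond the scatter.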